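Swapping the Amine Substituent Across Two Related Cores

The source may hold more compounds than are shown below. What is called first, only, known or untested is meant among the compounds shown, and "the series" means these compounds.

Four compounds share a common theme: a trimethoxy-substituted ring linked to a second ring that carries a methoxy group and an amide side chain ending in a small amine. They were tested in a functional assay on HeLa cells (Homo sapiens) for antiproliferative activity, read by MTT assay, with a stated time of 48 h; on this read-out lower numbers stand for stronger inhibition and higher numbers for weaker inhibition.

Compound 1 has the structure `CCNCC(=O)Nc1cc(OC)ccc1C(=O)c1cc(OC)c(OC)c(OC)c1`, and in this assay compound 1 gives 2100 nM. Compound 2 has the structure `COc1ccc(C(=O)c2cc(OC)c(OC)c(OC)c2)c(NC(=O)CN(C)C)c1`, and in this assay compound 2 gives 470 nM. Going by the values given here, the one change between them, (dimethylamino in place of ethylamino on a saturated chain carbon bound to a carbonyl carbon), produced a 4.5-fold lower number from compound 1 to compound 2 (0.65 log units; beyond the scatter).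

Compound 3 has the structure `C=C(c1cc(OC)c(OC)c(OC)c1)c1ccc(OC)cc1NC(=O)CNCC`, and in this assay compound 3 gives 430 nM. The difference between the core of compound 3 and the core of compound 1 is not broken down here. The numbers for compound 3 and compound 2 sit within the usual scatter of each other, so nothing can be said about which of the two is the more active.

Compound 4, not yet measured, has the structure `C=C(c1cc(OC)c(OC)c(OC)c1)c1ccc(OC)cc1NC(=O)CN(C)C`. It relates to compound 3 exactly as compound 2 relates to compound 1: the change is dimethylamino in place of ethylamino on a saturated chain carbon bound to a carbonyl carbon, the same change at the same place. Because that change gave a 4.5-fold lower number from compound 1 to compound 2 (0.65 log units; beyond the scatter), compound 4 is expected to show a lower number than compound 3, though it is uncertain whether a change seen once on one core carries over fully to a different core. The step from compound 3 to compound 4 is estimated at a 2.9-fold lower number from compound 3 to compound 4 (0.46 log units; beyond the scatter). Compound 4 is therefore expected to give about 150 nM, with a plausible range from 50 nM to 500 nM.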

Compound 4, half-maximal inhibitory concentration: 370 nM
Estimate against measurement, compound 4: 2.5-fold (0.39 log units) below, and the stated range covers the measured number.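

Putting dimethylamino in place of ethylamino on the core of compound 3 gave a 1.2-fold lower number from compound 3 to compound 4 (0.07 log units; within the scatter) in this assay, so on this core the measurement cannot separate the effect of the change from ordinary variation between repeated measurements. The gain seen on the first core did not carry over at the same size to the second: the same change on two cores in this assay, a 4.5-fold lower number (0.65 log units; beyond the scatter) from compound 1 to compound 2 and a 1.2-fold lower number (0.07 log units; within the scatter) from compound 3 to compound 4, 3.8-fold (0.58 log units) apart, beyond the scatter of two such steps. In these four compounds, then, the result of this change depends on the core that carries it, but two pairs cannot show which feature of the cores is responsible, or what the same change would do on a third core.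

The compounds shown leave open how other amines at the same place, such as a diethylamino group or an unsubstituted amino group, would behave on the two cores, and whether either would follow the pattern of the ethylamino and dimethylamino pairs. They also leave open whether a longer chain carrying the dimethylamino group would respond to the core in the same way.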